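Removing the Acetyl from the Acetamido Group of Compound 2

This account rests on a few compounds, and the source may have more. Where it says the series, first, only, none or still open, it means among the compounds named here.

Measured compounds:
Compound 1, `CC(=O)c1ccc2c(c1)N(C1=CCCC1=O)CC(C)(C)S2`, gives 88% in a functional assay on aorta (Rattus norvegicus, strain Wistar); on this read-out lower numbers stand for smaller maximal responses and higher numbers for larger maximal responses.
Compound 2, `CC(=O)Nc1ccc2c(c1)N(C1=CCCC1=O)CC(C)(C)S2`, gives 97% in this assay.

Among the compounds with values here, compound 2 is one of only two numbers so far, and the step of a number 9 percentage points higher from compound 1 to compound 2 (within the scatter) does not separate it from compound 1. Compound 3, `CC1(C)CN(C2=CCCC2=O)c2cc(N)ccc2S1`, is still unmeasured; its change from compound 2 is hydrogen in place of acetyl on a nitrogen on an aromatic ring. Within the data shown here, the one measured step changed the same aromatic position, acetamido in place of acetyl, and stayed within the scatter, but no step shows the acetamido-to-amino change itself. Compound 3 is therefore expected to move only within the scatter, a step of a number 5 percentage points lower from compound 2 to compound 3 (within the scatter), giving an estimated 92%, between 75% and 105%.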

Compound 3, largest response reached (Emax), in percent of the reference or control that the assay uses: 96%
Beside the measured number, compound 3's estimate is 4 percentage points below it; the range from low to high includes it.
By their numbers in this assay, from the lowest: compounds 1, 3 and 2 (each within the scatter of the next).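

In this assay the acetamido-to-amino change itself gives a number 1 percentage points lower from compound 2 to compound 3 (within the scatter) and so leaves the maximal response unresolved from that of the acetylated compound. Amino in place of acetyl on an aromatic carbon gives a number 8 percentage points higher from compound 1 to compound 3 (within the scatter) and adds a second step that stays inside the scatter, so acetyl, acetamido and amino cannot be told apart on this read-out. No measured information bears on this result. Still open, on these data alone, is whether a quite different group on this aromatic carbon, such as a carboxylic acid or a longer alkyl chain, would separate from these three.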